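The source may report more compounds than this note shows. Statements on the series, on what has been measured and on what is new or still open speak of the compounds shown alone.

Compound 1 `CC1(COC(=O)N2CC3COCC(C2)C3Oc2ncnc(Nc3ccc(C#N)cc3Cl)c2F)COC1`: 516 nM
Compound 2 `CC1(OC(=O)N2CC3COCC(C2)C3Oc2ncnc(Oc3ccccc3F)c2F)CC1`: 75 nM
Compound 3 `CC1(OC(=O)N2CC3COCC(C2)C3Oc2ncnc(Nc3ccc(F)cc3F)c2F)CC1`: 44 nM

In a functional assay for agonist activity at Glucose-dependent insulinotropic receptor (Mus musculus), read by cAMP accumulation (a higher number here means that more compound is needed for the effect, a lower number that less compound is needed), compound 1 gives 516 nM, the highest of the three numbers. Compound 2 gives 75 nM, and compound 3 gives 44 nM. Going by the values given here, the only step between measured compounds that differs in one place is a 1.7-fold lower number from compound 2 to compound 3 (0.23 log units; within the scatter), and it concerns the group on the aromatic carbon, not the carbamate part of the shared core.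

Compound 4 `N#Cc1ccc(Nc2ncnc(OC3C4COCC3CN(C(=O)OC3CCC3)C4)c2F)c(Cl)c1` differs from compound 1 by cyclobutyl in place of (3-methyloxetan-3-yl)methyl on an oxygen next to a carbonyl group. Among the compounds with values here, no measured pair isolates this change: compounds 2 and 3 carry a different group on that oxygen, but they also differ from compound 1 elsewhere, so their values show only that compounds with other carbamate groups and other aryl groups gave lower numbers, without separating the two changes. The measured step of a 1.7-fold lower number from compound 2 to compound 3 (0.23 log units; within the scatter) therefore gives no guide to the size or direction of this step.

The expectation for compound 4 is accordingly a step of a 1.3-fold lower number from compound 1 to compound 4 (0.11 log units; within the scatter), not beyond the scatter, with a wide range. The estimated value of compound 4 in this assay is 400 nM, expected between 130 nM and 1300 nM.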

Compound 4, half-maximal effective concentration: 60 nM
Compound 4: middle estimate off by 6.7-fold (0.82 log units), on the high side; measured number outside the range, below it.
By their numbers in this assay, from the lowest: compounds 3, 4 and 2 (each within the scatter of the next); then compound 1.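

In this assay, putting cyclobutyl in place of (3-methyloxetan-3-yl)methyl on an oxygen next to a carbonyl group, with the rest of the structure unchanged, gives an 8.6-fold lower number from compound 1 to compound 4 (0.93 log units; beyond the scatter). This shows that the group on this oxygen alone can move the number beyond the scatter, which compound 2 and compound 3 could not show, as both also differ from compound 1 elsewhere. The change removes heavy atoms and a hydrogen-bond acceptor together, so the pair cannot separate those two differences, and no evidence on the cause of the step is available.

Going by these compounds, it remains open whether this swap would have a similar effect with other groups on the aromatic carbon. On these data alone, how other groups on this oxygen, such as isopropyl or tert-butyl, would compare also remains open.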